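The source may hold more compounds than are shown below. What is called first, only, known or untested is meant among the compounds shown, and "the series" means these compounds.

Measured compounds:
Compound 1, `C[C@@H](NC(=O)c1ccc(C#CC2CCCC2)cn1)C(C)(C)O`, gives 14.8% in an ADME assay on HEK293 cells for agonist activity at metabotropic glutamate receptor 5 (Rattus norvegicus), read by fluorescence and calcium flux; a lower number here means a smaller maximal response, a higher number a larger maximal response.
Compound 2, `CC(C)[C@@H](C)NC(=O)c1ccc(C#Cc2cccc(F)c2)cn1`, gives 22.5% in this assay.

The two compounds share a core and differ in two places: the group on the amide-type nitrogen and the group at the other end of the shared core. In this assay compound 2 and compound 1 give numbers that lie within the usual scatter of each other, so neither can be set above the other; both reach only a small part of the full response of the reference.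

Compound 3, `CC(C)(CO)NC(=O)c1ccc(C#Cc2cccc(F)c2)cn1`, is not yet measured. It keeps everything of compound 2 except one group: 1-(hydroxymethyl)-1-methylethyl in place of 1,2-dimethylpropyl on an amide-type nitrogen. The group that enters carries a hydroxyl, as does the group on the amide-type nitrogen of compound 1, which in this assay gives 14.8%. Among the measured compounds shown here, no measured pair isolates this single change, so the expectation rests on the two numbers alone. Compound 3 is expected to move a number 4.5 percentage points lower from compound 2 to compound 3 (within the scatter), a step not beyond the scatter. The estimate for compound 3 is 18%, with a range from 6% to 34%.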

Compound 3, largest response reached (reported as efficacy), in percent of the reference or control that the assay uses: 9.3%
The estimate for compound 3 lay 8.7 percentage points above the measured number; measured number inside the range.
By their numbers in this assay, from the lowest: compounds 3, 1 and 2 (each within the scatter of the next, the first and the last beyond it).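

In this assay, among the compounds shown here, placing 1-(hydroxymethyl)-1-methylethyl instead of 1,2-dimethylpropyl on the amide-type nitrogen gives a number 13.2 percentage points lower from compound 2 to compound 3 (beyond the scatter), the first single change here whose effect can be read on its own, and it shows that the maximal response depends on the group at this position. Both groups hold 5 heavy atoms, but the entering group brings an oxygen, with a hydrogen-bond donor and a hydrogen-bond acceptor, and lacks the defined stereocentre of the leaving group, so several features change in this one step. No measurement shown here says what lies behind the step, and this single pair cannot tell which of those features matters.

Compound 1 differs from compound 3 in two places, so it cannot show whether the same change would have a similar effect with a different group at the other end of the shared core. From the compounds shown here alone, it also remains open how the response would change if an amine or a methoxy group stood in place of the hydroxyl, or if a longer chain carried the hydroxyl on the amide-type nitrogen.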